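A few compounds are considered here, and "the series" means these few. Any claim that something is new, unique, unknown or untested is made for them only; others in the source may bear on it.

Measured compounds:
Compound 1, `Cn1c(=O)c2nn(C3CCCC3)nc2n(C)c1=O`, gives 110000 nM.
Compound 2, `CCCn1c(=O)c2nn(C3CCCC3)nc2n(CCC)c1=O`, gives 1300 nM.
Compound 3, `CCCn1c(=O)c2c(nnn2-c2ccc(Cl)cc2N)n(CCC)c1=O`, gives 44000 nM.

All three numbers come from an assay on cell membranes from brain for displacement of a labelled ligand from adenosine receptor A1 (Bos taurus); on this read-out higher numbers stand for weaker inhibition and lower numbers for stronger inhibition. Among them compound 2 holds the lowest number, and both gaps to it lie beyond the usual scatter: compound 3 stands well above it, and compound 1 higher still. Compound 4, `CCCn1c(=O)c2nn(C3CCCCC3O)nc2n(CCC)c1=O`, is built from compound 2 by a single change: 2-hydroxycyclohexyl in place of cyclopentyl on an aromatic nitrogen. Within the data shown here, no two measured compounds differ only in this group, so the size of such a step cannot be read from the numbers at hand; the other two measured compounds differ from compound 2 in other parts of the shared core and say nothing direct about the group on the aromatic nitrogen. It is therefore expected that compound 4 gives a step of moderate size in this assay, towards a higher number than compound 2 rather than a lower one, with a real chance that the change stays within the scatter. The step that this expectation means is a 3.8-fold higher number from compound 2 to compound 4 (0.59 log units; beyond the scatter). On this basis compound 4 is estimated at 5000 nM, with a likely range from 1500 nM to 20000 nM.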

Compound 4, inhibition constant: 1400 nM
Beside the measured number, compound 4's estimate is 3.6-fold (0.55 log units) above it; the measured number lies below the stated range.
By their numbers in this assay, from the lowest: compounds 2 and 4 (each within the scatter of the next); then compound 3; then compound 1.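

In this assay, among these compounds, the step at this position, a 1.1-fold higher number from compound 2 to compound 4 (0.03 log units; within the scatter), stays within the scatter, and it is the first step that can be read for a group on this aromatic nitrogen. The numbers therefore separate 2-hydroxycyclohexyl from cyclopentyl at this site by no real margin, even though the entering group brings a six-membered ring, an oxygen, a hydrogen-bond donor and a hydrogen-bond acceptor to a place that held a five-membered ring of carbon only. Nothing available accounts for this result, so the equal standing of the two groups remains an observation on this single pair.

The change alters ring size and adds a hydroxyl in one step, so the compounds shown cannot say what each alteration contributes alone, and plain cyclohexyl or 2-hydroxycyclopentyl would be needed to separate them. From the compounds shown here alone, it also remains open whether this position would tolerate an amine or a carboxylic acid on the ring in place of the hydroxyl, or whether 2-hydroxycyclohexyl would fare the same on the core of compound 1.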